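Swapping methyl for phenyl on the amide nitrogen

This account rests on a few compounds, and the source may have more. Where it says the series, first, only, none or still open, it means among the compounds named here.

Of the compounds shown here, two have been measured so far in a functional assay on A549 cells (Homo sapiens) for antiproliferative activity, read by CCK-8 assay, with a stated time of 48 h; a higher number here means a weaker inhibitor, a lower number a stronger inhibitor. Compound 1 `O=C(Nc1ccccc1)c1cc(Oc2ccc(/C=C/c3ccccn3)cc2)ccn1` gives 19100 nM, and compound 2 `CNC(=O)c1cc(Oc2ccc(/C=C/c3ccncc3)cc2)ccn1` gives 13200 nM. These two compounds differ from each other in more than one place, and their numbers lie within the usual scatter of each other, so neither can be called stronger or weaker than the other. Compound 2 has the lowest number of the two, with compound 1 close behind it.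

The next compound, compound 3 `O=C(Nc1ccccc1)c1cc(Oc2ccc(/C=C/c3ccncc3)cc2)ccn1`, is compound 2 with one change: phenyl in place of methyl on an amide-type nitrogen. For the measured compounds named here, no measured pair differing only in this way exists among the compounds above, so the size of the step from compound 2 to compound 3 in this assay cannot be read off directly. Compound 1, which also carries the phenylcarbamoyl group, gives 19100 nM, a weak number in the same range as compound 2. Compound 3 is therefore expected to stay in that range, with a step from compound 2 of a 1.1-fold higher number from compound 2 to compound 3 (0.06 log units; within the scatter), not beyond the scatter. The estimate for compound 3 is 15000 nM, within a range from 5000 nM to 45000 nM.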

Compound 3, half-maximal inhibitory concentration: 79700 nM
For compound 3 the middle estimate is 5.3-fold (0.73 log units) below the measured one; the measured number lies above the stated range.
By their numbers in this assay, from the lowest: compounds 2 and 1 (each within the scatter of the next); then compound 3.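

In this assay, the group on the amide nitrogen clearly matters: with the pyridin-4-yl group held constant, phenyl in place of methyl gives a 6.0-fold higher number from compound 2 to compound 3 (0.78 log units; beyond the scatter), a step beyond the scatter that the earlier pair could not show. The pyridine group matters too: with the phenylcarbamoyl group held constant, pyridin-4-yl in place of pyridin-2-yl gives a 4.2-fold higher number from compound 1 to compound 3 (0.62 log units; beyond the scatter), also beyond the scatter, so each of these two single changes separately leaves a weaker inhibitor. No measurement shown here explains why either change has this result.

The compounds shown leave open how the number would respond to other groups on the amide nitrogen, such as ethyl, a longer chain or benzyl, and therefore whether the loss follows gradually from methyl to phenyl or is specific to phenyl. It also remains open whether phenyl in place of methyl has a step of similar size when pyridin-2-yl is present, as the compounds shown include no such pair.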